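From Compound 3 to Compound 4: Pentyl to Benzyl

This account rests on a few compounds, and the source may have more. Where it says the series, first, only, none or still open, it means among the compounds named here.

In a functional assay on NCI-H460 cells (Homo sapiens) for antiproliferative activity, read by MTT assay, with a stated time of 48 h (on this read-out lower numbers stand for stronger inhibition and higher numbers for weaker inhibition), compound 1 (`Cc1ccc(Nc2ccc3c(c2)C(CCC(C)C)C(=O)N3)cc1`) gives 55300 nM and compound 2 (`CCCCCC1(O)C(=O)Nc2ccc(Nc3ccc(OC)cc3)cc21`) gives 16200 nM. Compound 3 (`CCCCCC1(O)C(=O)Nc2ccc(Nc3ccc(C)cc3)cc21`) gives > 100000 nM in this assay, which is a limit of the assay and not a number. The series thus holds (the limit of > 100000 nM in this assay, at which 1 of the 3 values shown sits).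

Compound 4 (`Cc1ccc(Nc2ccc3c(c2)C(O)(Cc2ccccc2)C(=O)N3)cc1`) departs from compound 3 at a single place: phenyl in place of butyl on a saturated chain carbon bound to a saturated ring carbon. This is phenyl in place of butyl on a saturated chain carbon bound to a saturated ring carbon, or pentyl to benzyl when cut one bond further out.

For the measured compounds named here, no measured step covers this change. The only one, an at least 6.1-fold higher number from compound 2 to compound 3 (0.79 log units; beyond the scatter), is methyl in place of methoxy on an aromatic carbon, and it serves only as a gauge of how far one change can move the numbers here. A move to a lower number, smaller than that step, is expected, though a reading at the limit remains quite possible. The expected change is an at least 2.0-fold lower number from compound 3 to compound 4 (0.30 log units; that floor lies within the scatter). For compound 4 the estimate is 50000 nM, with an expected range of 15000 nM to 100000 nM.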

Compound 4, half-maximal inhibitory concentration: 31600 nM
For compound 4 the middle estimate is 1.6-fold (0.20 log units) above the measured one; the range from low to high includes it.
By their numbers in this assay, from the lowest: compounds 2, 4 and 1 (each within the scatter of the next, the first and the last beyond it). At a limit, above all of these: compound 3.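

For the compounds shown here, until now, the only step read was a change on an aromatic carbon; this one shows that the saturated chain carbon bound to a saturated ring carbon also affects the read-out. In this assay the change of butyl to phenyl there gives an at least 3.1-fold lower number from compound 3 to compound 4 (0.50 log units; beyond the scatter), and compound 4 returns a measurable number. The true size of the step stays unknown, and only its floor can be read, because one end of it is a limit of the assay: the limit of > 100000 nM in this assay, at which 1 of the 4 values shown sits.

Going by these compounds, it remains open whether this shift requires the aromatic ring itself or only a larger carbon group, which a cyclohexylmethyl group or a longer chain at this place would help separate. Also open, on these data alone, is whether an amine or a carboxylic acid on the benzyl ring would be tolerated.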